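A few compounds are considered here, and "the series" means these few. Any claim that something is new, unique, unknown or untested is made for them only; others in the source may bear on it.

Measured so far in a physicochemical assay for lipophilicity, using the shake flask method (on this read-out higher numbers stand for higher lipophilicity and lower numbers for lower lipophilicity), for two compounds:
- compound 1 `C[C@H](Oc1ccc2ncc(/C=C/C(=O)O)c(C#N)c2c1)c1c(Cl)ccc(F)c1Cl` gives 2.3
- compound 2 `CC(Oc1ccc2ncc(/C=C/C(=O)O)c(C3CC3)c2c1)c1c(Cl)cccc1C#N` gives 2.2

Compound 1 holds the highest number of the two, but compound 2 lies within the scatter of it, so the pair stands level and no order can be read from it. Compound 3 `C[C@H](Oc1ccc2ncc(/C=C/C(=O)O)c(O)c2c1)c1c(Cl)ccc(F)c1Cl` keeps the core of compound 1 and changes one group, with hydroxy in place of cyano on an aromatic carbon as the counted difference: hydroxy in place of cyano on an aromatic carbon, ortho to a 2-carboxyethenyl group and opposite the ring nitrogen. Among the compounds with values here, no measured step between compounds differing in one place is available, so the expectation rests on the structural change alone. A downward step in this assay is expected, probably beyond the scatter, though this is not secure. The estimated move is a number 0.50 log units lower from compound 1 to compound 3 (beyond the scatter) for this exchange. Compound 3 is expected at 1.8 with an estimated range from 1.2 to 2.4 in these notes.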

Compound 3, distribution coefficient: 1.9
Compound 3: the middle estimate sits 0.10 log units below what was measured; the measured number falls inside the stated range.
By their numbers in this assay, from the lowest: compounds 3, 2 and 1 (each within the scatter of the next, the first and the last beyond it).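

On an aromatic carbon ortho to a 2-carboxyethenyl group and opposite the ring nitrogen, the exchange of cyano for hydroxy gives the series its first step between compounds differing in one place: the read-out in this assay stands a number 0.40 log units lower from compound 1 to compound 3 (beyond the scatter). The read-out at this position therefore depends on the group it carries, which compound 1 and compound 2 could not show, as that pair differs in more than one place and stands level. Within the data shown here, nothing measured so far accounts for this step.

As far as these compounds go, this is a single exchange on a single background, so it remains open whether the step would carry over to other substituents on the shared core. From the compounds shown here alone, how an amine or a methoxy group on this same carbon would stand against hydroxy and cyano also remains open.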